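Swapping a Methyl for a Chloromethoxyphenyl on a Sulfonyl

The source may hold more compounds than are shown below. What is called first, only, known or untested is meant among the compounds shown, and "the series" means these compounds.

Compound 2 `CS(=O)(=O)Nc1ccc(-c2nc3ccccc3o2)cc1` carries a methylsulfonamide. In an assay on cells for inhibition of HSP60/HSP10 (Homo sapiens), with a stated time of 60 min (a higher number here means a weaker inhibitor, a lower number a stronger inhibitor), compound 2 reaches only the limit of the assay, > 100000 nM, so no number is known for it. Compound 1 `CS(=O)(=O)Nc1ccc(-c2nc3cc(NS(=O)(=O)c4ccc(Cl)s4)ccc3o2)cc1` adds a ((5-chlorothiophen-2-yl)sulfonyl)amino group elsewhere on the shared core and gives 43000 nM. Compound 3 `O=S(=O)(Nc1ccc2oc(-c3ccccc3)nc2c1)c1ccccc1Cl`, which bears an aryl sulfonamide and a plain phenyl instead of the methylsulfonamide, also sits at the limit, > 100000 nM. Going by the values given here, the one measured step, an at least 2.3-fold higher number from compound 1 to compound 2 (0.36 log units; beyond the scatter), shows that taking away that second sulfonamide makes inhibition weaker, and the limit of > 100000 nM in this assay, at which 2 of the 3 values shown sit, shows how often the limit appears in this set.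

Compound 4 `COc1ccc(Cl)cc1S(=O)(=O)Nc1ccc(-c2nc3ccccc3o2)cc1` differs from compound 2 by 5-chloro-2-methoxyphenyl in place of methyl on a sulfonyl sulfur. Among the compounds with values here, this change touches a place that no measured step covers, so its direction cannot be read from the data. Since two of three compounds sit at the limit, compound 4 is expected to remain a weak inhibitor, with an estimated step of an at least 1.4-fold lower number from compound 2 to compound 4 (0.15 log units; that floor lies within the scatter). Compound 4 is estimated at 70000 nM, within 25000 nM to 200000 nM.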

Compound 4, half-maximal inhibitory concentration: > 100000 nM
Compound 4 was reported as a limit (the forecaster's own chance of this, stated with the estimate: 55%); middle value at least 1.4-fold (0.15 log units) away from the limit.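

No step can be read between compound 2 and compound 4, since each is reported only as a limit in this assay: the limit of > 100000 nM in this assay, at which 3 of the 4 values shown sit. From the compounds shown here alone, whether 5-chloro-2-methoxyphenyl in place of methyl on a sulfonyl sulfur changes inhibition at all remains open.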